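The compounds below may be only part of what the source reports. "The series", "measured", "known", "first", "only" and "open" are said of these compounds alone.

Measured so far in an ADME assay on HepG2 2.2.15 cells (Homo sapiens) for cytotoxicity, read by MTT assay, with a stated time of 8 days; a higher number here means that more compound is tolerated, a lower number that less compound is tolerated:
Compound 1 `CC(=O)Nc1ccc(-c2nn(Cc3ccc(C#N)cc3)c(=O)c3ccccc23)c(F)n1`: > 100000 nM
Compound 2 `N#Cc1ccc(Cn2nc(-c3cc(Cl)c(NCCO)nc3F)c3ccccc3c2=O)cc1`: 32100 nM

The value of compound 1, > 100000 nM, is a limit of the assay and not a number. Within the data shown here, compound 2, at 32100 nM, therefore holds the only actual number so far. Compound 3 `N#Cc1ccc(Cn2nc(-c3cc(Cl)c(NCC(O)CO)nc3F)c3ccccc3c2=O)cc1` differs from compound 2 by hydroxymethyl in place of hydrogen on a saturated chain carbon bound to an oxygen on a saturated carbon and a saturated chain carbon, which turns the (2-hydroxyethyl)amino into (2,3-dihydroxypropyl)amino. Among the measured compounds shown here, no measured step shows this change. A small move towards more compound tolerated is expected, an estimated 1.2-fold higher number from compound 2 to compound 3 (0.10 log units; within the scatter), within the usual scatter. For compound 3, the half-maximal cytotoxic concentration in this assay is estimated at 40000 nM, with an expected range of 15000 nM to 100000 nM.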

Compound 3, half-maximal cytotoxic concentration: > 100000 nM
Compound 3 gave a limit, no number (the forecaster's own chance of this, stated with the estimate: 20%); middle value at least 2.5-fold (0.39 log units) from the limit.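

In this assay, hydroxymethyl in place of hydrogen on this saturated chain carbon, which turns (2-hydroxyethyl)amino into (2,3-dihydroxypropyl)amino, gives an at least 3.1-fold higher number from compound 2 to compound 3 (0.49 log units; beyond the scatter). Among these compounds, this is the first single change that can be read at this position, and it lies beyond the scatter. Compound 3 gives > 100000 nM, which is a limit of the assay and not a number: the limit of > 100000 nM in this assay, at which 2 of the 3 values shown sit.

On these data alone, the true size of the step stays open. As far as these compounds go, it also stays open what a methoxymethyl, an aminomethyl or a carboxylic acid would do in place of this hydroxymethyl.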